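Isopentyl in place of 3-methylphenyl on compound 1

A few compounds are considered here, and "the series" means these few. Any claim that something is new, unique, unknown or untested is made for them only; others in the source may bear on it.

Three compounds have values so far in an ADME assay on Caco-2 cells (Homo sapiens) for permeability, read by LC-MS, in the apical to basolateral direction, with a stated time of 60 min, at pH 6.5 (a lower number here means that the compound crosses the layer more slowly, a higher number that the compound crosses the layer faster), as follows:
- compound 1 (`Cc1cccc([C@@H](O)C(=O)N2N=CC[C@H]2C(=O)NCc2cc(Cl)ccc2-n2cnnn2)c1`), value (9.7 10^-6 cm/s)
- compound 2 (`CC(C)(C)OC[C@@H](O)C(=O)N1[C@H](C(=O)NCc2cc(Cl)ccc2-n2cnnn2)C[C@@H]2C[C@@H]21`), value (4.5 10^-6 cm/s)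
- compound 3 (`O=C(NCc1cc(Cl)ccc1-n1cnnn1)[C@@H]1C[C@H]2C[C@H]2N1C(=O)[C@H](O)c1ccccc1`), value (17 10^-6 cm/s)

Compound 1 stands within the scatter of compound 3 and beyond the scatter from compound 2, which has the lower number.

Compound 4 (`CC(C)CC[C@@H](O)C(=O)N1N=CC[C@H]1C(=O)NCc1cc(Cl)ccc1-n1cnnn1`) has not yet been measured. It differs from compound 1 by a single change (isopentyl in place of 3-methylphenyl on a saturated chain carbon bound to a carbonyl carbon and an oxygen on a saturated carbon): isopentyl in place of 3-methylphenyl on a saturated chain carbon bound to a carbonyl carbon and an oxygen on a saturated carbon.

Among the measured compounds shown here, no step between measured compounds shows such a change, so there is no direct guide. Compound 1 and compound 3 carry an aromatic ring on that carbon. Compound 2 has none there and gives (4.5 10^-6 cm/s), but its core differs from that of compound 1, which makes it a weak pointer.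

On that slender basis, the expected move is (a 1.4-fold lower number from compound 1 to compound 4 (0.14 log units; within the scatter)), a small downward step not expected to go clearly beyond the scatter. For compound 4 the estimated value is 7 10^-6 cm/s with an expected range from 3 10^-6 cm/s to 16 10^-6 cm/s in this assay when it is measured.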

Compound 4, apparent permeability: 29 10^-6 cm/s
Estimate against measurement, compound 4: 4.1-fold (0.62 log units) below, and the stated range ends below it.
By their numbers in this assay, from the lowest: compound 2; then compounds 1, 3 and 4 (each within the scatter of the next, the first and the last beyond it).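

In this assay, among the compounds shown here, the first reading at this saturated chain carbon is isopentyl in place of 3-methylphenyl on the core of compound 1, which gives a 3.0-fold higher number from compound 1 to compound 4 (0.48 log units; beyond the scatter). For the compounds shown here, on this core, then, the six-membered aromatic ring is not needed for a high number, since compound 4, with no ring at that carbon, reaches 29 10^-6 cm/s; compound 2 and compound 3 differ from compound 4 in more than one place, and no step to either can be read. Nothing measured here accounts for the rise.

This one pair swaps an aromatic ring for an open chain and also goes from seven carbons to five, so it cannot separate these differences, and a cyclohexyl group on that carbon would help to tell them apart. Also open, going by these compounds, is whether a longer chain or a chain ending in an amine would hold the number seen for compound 4, and whether isopentyl would give a step of similar size on the core of compound 3.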